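The compounds below may be only part of what the source reports. "The series", "measured", "known", "first", "only" and "open" are said of these compounds alone.

Working notes on the series. Compound 1 `Cc1ccc(-c2nn(-c3ccccc3)cc2C(=O)NOCc2ccccc2)cc1` gives 6690 nM in a functional assay on HeLa cells (Homo sapiens) for antiproliferative activity, read by MTT assay, with a stated time of 48 h, in the presence of a further agent that is not named here; on this read-out higher numbers stand for weaker inhibition of growth and lower numbers for stronger inhibition of growth. Compound 2 `Cc1ccc(-c2nn(-c3ccccc3)cc2C(=O)NOCc2ccccc2F)cc1` differs from compound 1 by fluoro in place of hydrogen on an aromatic carbon, and in this assay compound 2 gives 1180 nM, a step of a 5.7-fold lower number from compound 1 to compound 2 (0.75 log units; beyond the scatter). Compound 3 `O=C(NOCc1ccccc1)c1cn(-c2ccccc2)nc1-c1ccc(F)cc1` differs from compound 1 in the core by fluoro in place of methyl on an aromatic carbon; in this assay compound 3 gives 6110 nM, a step of a 1.1-fold lower number from compound 1 to compound 3 (0.04 log units; within the scatter), so the two cores sit within the scatter of one another. Compound 4 `O=C(NOCc1ccccc1F)c1cn(-c2ccccc2)nc1-c1ccc(F)cc1` has not yet been measured. Going by the values given here, it differs from compound 3 by fluoro in place of hydrogen on an aromatic carbon, which is the same change, at a place described in the same words, as the one from compound 1 to compound 2. Since the two cores gave numbers within the scatter of each other (a 1.1-fold lower number from compound 1 to compound 3 (0.04 log units; within the scatter)), the step seen earlier is expected to carry over to compound 4 in this assay. For compound 4 the expected step is a 5.1-fold lower number from compound 3 to compound 4 (0.71 log units; beyond the scatter), set beside a 5.7-fold lower number from compound 1 to compound 2 (0.75 log units; beyond the scatter). Compound 4 is therefore estimated at 1200 nM, with a range from 500 nM to 3000 nM.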

Compound 4, concentration for 50% growth inhibition: 10300 nM
Estimate against measurement, compound 4: 8.6-fold (0.93 log units) below; measured number above the stated range.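

In this assay, the change from benzyl to 2-fluorobenzyl does not carry over from one core to the other: on the core of compound 3 it gives a 1.7-fold higher number from compound 3 to compound 4 (0.23 log units; within the scatter), and the gap to the step on the core of compound 1 stands as follows: the same change on two cores in this assay, a 5.7-fold lower number (0.75 log units; beyond the scatter) from compound 1 to compound 2 and a 1.7-fold higher number (0.23 log units; within the scatter) from compound 3 to compound 4, 9.6-fold (0.98 log units) apart, beyond the scatter of two such steps

The same non-additivity appears when the pairs are read through the other change, fluoro in place of methyl on the core, where the 2-fluorobenzyl pair gives an 8.7-fold higher number from compound 2 to compound 4 (0.94 log units; beyond the scatter), and the two readings compare thus: the same change on two cores in this assay, a 1.1-fold lower number (0.04 log units; within the scatter) from compound 1 to compound 3 and an 8.7-fold higher number (0.94 log units; beyond the scatter) from compound 2 to compound 4, 9.6-fold (0.98 log units) apart, beyond the scatter of two such steps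

This shows that, among these four compounds, the effect of the fluoro depends on the core, and that agreement between compound 1 and compound 3 did not make the step transferable; it does not show why the cores differ, nor how any further core would behave.

The compounds shown leave open whether a chloro or a methoxy in place of the fluoro on the benzyl would also depend on the core. An amine or a carboxylic acid in place of the methyl on the core also remains an open case.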